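A Methyl Added to the Ring Carbon of Compound 1

The source may hold more compounds than are shown below. What is called first, only, known or untested is meant among the compounds shown, and "the series" means these compounds.

The series rests on a shared core, shown in compound 1 `COCCN/C(=C1/N=CN(CCOC)C1=O)c1cc2ccccc2[nH]1`, and was tested in an assay on isolated protein for inhibition of Calpain-1 catalytic subunit (Homo sapiens), read by fluorescence, with a stated time of 60 min, tested at 1 uM; a lower number here means less inhibition, a higher number more inhibition at the concentration tested (going by the name of the read-out). In this assay compound 1 gives 73.7%, the higher of the two numbers recorded so far. Its nearest companion, compound 2 `CC(C)N/C(=C1/N=CN(C(C)C)C1=O)c1cc2ccccc2[nH]1`, carries isopropyl groups in place of the two 2-methoxyethyl groups, and in this assay compound 2 gives 57.8%, a gap below compound 1 that lies beyond the scatter of repeated measurements.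

Compound 3 `COCCN/C(=C1/N=C(C)N(CCOC)C1=O)c1cc2ccccc2[nH]1` has not been measured. It differs from compound 1 in one place: methyl in place of hydrogen on a carbon with a double bond to nitrogen. Within the data shown here, no step between measured compounds reports what such a change does, so any expectation must lean on the change itself and on the level of compound 1.

Compound 3 is expected to sit close to compound 1, with a step of a number 8.7 percentage points lower from compound 1 to compound 3 (within the scatter) that may well fall within the scatter and is more likely to point downward than upward. The estimate for compound 3 in this assay is 65%, with a range from 38% to 88%.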

Compound 3, a percentage reported as inhibition, at one concentration (the size of the read-out at that concentration, not a potency): 93%
The estimate for compound 3 lay 28 percentage points below the measured number; measured number above the stated range.
By their numbers in this assay, from the lowest: compound 2; then compound 1; then compound 3.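

The step shows that this carbon, between two ring nitrogen atoms, can carry a substituent without loss of inhibition: in this assay, methyl in place of hydrogen gives a number 19.3 percentage points higher from compound 1 to compound 3 (beyond the scatter). Compound 1 and compound 2 both have hydrogen on this carbon, so they could say nothing about a change here, and this single added carbon now proves to matter to the read-out. Nothing available accounts for the rise, so the reason for it remains unknown.

The compounds shown leave open whether the gain belongs to methyl alone or would carry over to an ethyl group, a longer chain, a trifluoromethyl group or an amine on the same carbon. They also leave open whether methyl would give a similar step on the compound 2 background, with isopropyl groups in place of the two 2-methoxyethyl groups, and, since the read-out is taken at one concentration, how the step would translate into potency.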